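A few compounds are considered here, and "the series" means these few. Any claim that something is new, unique, unknown or untested is made for them only; others in the source may bear on it.

In a functional assay on MCF7 cells (Homo sapiens) for cytotoxicity, read by WST assay, with a stated time of 72 h (on this read-out higher numbers stand for weaker inhibition and lower numbers for stronger inhibition), compound 1 `O=C1Nc2c(ccc(F)c2F)C1(c1ccc(O)cc1)c1cccs1` gives 82 nM and compound 2 `O=C1Nc2c(ccc(F)c2F)C1(c1ccc(O)cc1)c1cccnc1` gives 63 nM. These two numbers lie within the scatter of each other, so compound 2 stands level with compound 1 and sets a strong starting point in the nanomolar range.

Compound 3 `CCCCCC1(c2ccc(O)cc2)C(=O)Nc2c1ccc(F)c2F` keeps the shared core and differs from compound 2 in a single group. The counted difference is pentyl in place of pyridin-3-yl on a saturated ring carbon.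

Among the compounds with values here, only one measured step bears on this change, a 1.3-fold lower number from compound 1 to compound 2 (0.11 log units; within the scatter). It shows that one aromatic ring could replace another at this carbon with no change beyond the scatter. However, it exchanges ring for ring, and no measured compound carries an open chain here, so the guidance is thin.

A modest move towards weaker inhibition in this assay therefore seems the likeliest outcome, though a result level with compound 2 remains possible. The expected change is a 2.5-fold higher number from compound 2 to compound 3 (0.40 log units; beyond the scatter).

For compound 3, the estimated value is 160 nM, with an expected range from 40 nM to 700 nM.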

Compound 3, half-maximal inhibitory concentration: 96 nM
Beside the measured number, compound 3's estimate is 1.7-fold (0.22 log units) above it; the measured number falls inside the stated range.
By their numbers in this assay, from the lowest: compounds 2, 1 and 3 (each within the scatter of the next).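

Swapping the aromatic ring for pentyl gives a 1.5-fold higher number from compound 2 to compound 3 (0.18 log units; within the scatter) in this assay, and the same swap against the thiophen-2-yl group gives a 1.2-fold higher number from compound 1 to compound 3 (0.07 log units; within the scatter), so all three compounds stand level. The earlier pair exchanged only one aromatic ring for another, whereas this result shows that the saturated ring carbon can carry an open chain with no ring and no hydrogen-bond acceptor and keep its number in the same nanomolar range, so among these three compounds an aromatic ring at this carbon is not needed to hold that number. Nothing available here explains why such different groups give numbers within the scatter of each other.

The compounds shown leave open how far this freedom extends, since a single chain length cannot show whether a methyl group or a longer chain such as decyl would also stay level with pentyl. They also leave open whether a chain ending in an amine or a carboxylic acid would hold the number at this carbon, or whether a saturated ring such as cyclohexyl would.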